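Changing the Ester Tail of Compound 1

The compounds below may be only part of what the source reports. "The series", "measured", "known", "first", "only" and "open" are said of these compounds alone.

Compound 1, `COC(=O)CCN1CCN(c2c(F)cc3c(=O)c(C(=O)O)cn(C4CC4)c3c2OC)CC1C`. In an ADME assay on Vero cells (Chlorocebus sabaeus) for cytotoxicity, read by MTT assay, with a stated time of 72 h (a higher number here means that more compound is tolerated, a lower number that less compound is tolerated), compound 1 gives > 1000 ug/mL, which is a limit of the assay and not a number.
Compound 2, `COc1c(N2CCN(C/C(C)=N/Nc3ccccc3)C(C)C2)c(F)cc2c(=O)c(C(=O)O)cn(C3CC3)c12`. Compound 2 gives 11.1 ug/mL.
Compound 3, `COc1c(N2CCN(CC/C(C)=N/O)C(C)C2)c(F)cc2c(=O)c(C(=O)O)cn(C3CC3)c12`. Compound 3 gives 44.2 ug/mL.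

Compound 1 therefore stands at the top of what the assay can report, known only as a limit (the limit of > 1000 ug/mL in this assay, at which 1 of the 3 values shown sits). Compound 4, `CO/N=C(\C)CCN1CCN(c2c(F)cc3c(=O)c(C(=O)O)cn(C4CC4)c3c2OC)CC1C`, differs from compound 1 by a group of 5 heavy atoms (3 carbon, 1 nitrogen, 1 oxygen; no ring) in place of a group of 4 heavy atoms (2 carbon, 2 oxygen; no ring), on a saturated chain carbon, two bonds along the chain from an amine nitrogen in a ring. The most comparable measured step is an at least 22-fold lower number from compound 1 to compound 3 (1.35 log units; beyond the scatter), where a group of the same size entered at the same place. A change at the neighbouring position also lowered the number: an at least 90-fold lower number from compound 1 to compound 2 (1.95 log units; beyond the scatter). Every measured departure from the methoxycarbonyl tail thus brought a large fall, so compound 4 is expected to fall as well, by about an at least 25-fold lower number from compound 1 to compound 4 (1.39 log units; beyond the scatter). The estimate for compound 4 is 40 ug/mL, expected between 10 ug/mL and 200 ug/mL.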

Compound 4, half-maximal cytotoxic concentration: 157 ug/mL
Compound 4: middle estimate off by 3.9-fold (0.59 log units), on the low side; the range from low to high includes it.
By their numbers in this assay, from the lowest: compound 2; then compound 3; then compound 4. At a limit, above all of these: compound 1.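

The smallest change so far, methyl in place of hydrogen on an oxygen, gives a 3.6-fold higher number from compound 3 to compound 4 (0.55 log units; beyond the scatter) in this assay. The tail of compound 4 also compares well with the one carrying the six-membered aromatic ring, with a 14-fold higher number from compound 2 to compound 4 (1.15 log units; beyond the scatter), yet the methoxycarbonyl tail still stands apart, with an at least 6.3-fold lower number from compound 1 to compound 4 (0.80 log units; beyond the scatter). Compound 1 is known only as a limit, and that last step is a minimum: the limit of > 1000 ug/mL in this assay, at which 1 of the 4 values shown sits.

Still open, from the compounds shown here alone, is whether a longer chain on that oxygen, such as ethyl, would raise the number further. Also open, going by these compounds, is how a carboxylic acid or an amine would fare in the place of the methoxycarbonyl.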